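The compounds below may be only part of what the source reports. "The series", "measured", "known", "first", "only" and "open" are said of these compounds alone.

Of the compounds shown here, three sharing one core have been tested in a functional assay on KB cells (Homo sapiens) for antiproliferative activity, read by sulforhodamine B assay, with a stated time of 3 days; a higher number here means that more compound is needed for the effect, a lower number that less compound is needed. Compound 1 `CCC1=C(O)c2c(oc(-c3ccc(CC)cc3)cc2=O)C(CC)(CC)C1=O` gives 21.9 uM and compound 2 `CCC1=C(O)c2c(oc(-c3ccc(O)cc3)cc2=O)C(CC)(CC)C1=O` gives 20.6 uM, a 1.1-fold lower number from compound 1 to compound 2 (0.03 log units; within the scatter). Compound 3 `CCC1=C(O)c2c(oc(-c3cccc(F)c3)cc2=O)C(CC)(CC)C1=O` gives only a limit, > 56.2 uM. Compound 4 `CCC1=C(O)c2c(oc(-c3ccc(C)cc3C)cc2=O)C(CC)(CC)C1=O` carries 2,4-dimethylphenyl in place of 3-fluorophenyl (2,4-dimethylphenyl in place of 3-fluorophenyl on an aromatic carbon). Within the data shown here, two measured steps bear on this change, both ending at 3-fluorophenyl: an at least 2.5-fold higher number from compound 1 to compound 3 (0.40 log units; beyond the scatter) and an at least 2.7-fold higher number from compound 2 to compound 3 (0.43 log units; beyond the scatter). The entering group looks closer to the 4-ethylphenyl of compound 1, which gives 21.9 uM, so that value is the expected guide. A step of similar size toward a lower number is therefore expected, an estimated at least 2.2-fold lower number from compound 3 to compound 4 (0.35 log units; beyond the scatter). For compound 4 the expected value is 25 uM, with an estimated range of 10 uM to 60 uM.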

Compound 4, concentration for half-maximal effect: 41.2 uM
Estimate against measurement, compound 4: 1.6-fold (0.22 log units) below; low and high end bracket the measured number.
By their numbers in this assay, from the lowest: compounds 2, 1 and 4 (each within the scatter of the next). At a limit, above all of these: compound 3.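

Placed at this position, 2,4-dimethylphenyl gives a 1.9-fold higher number from compound 1 to compound 4 (0.27 log units; within the scatter) and a 2.0-fold higher number from compound 2 to compound 4 (0.30 log units; within the scatter), so a third aryl group fits with compound 1 and compound 2 without a step beyond the scatter. In this assay, the change from 3-fluorophenyl gives an at least 1.3-fold lower number from compound 3 to compound 4 (0.13 log units; that floor lies within the scatter), which is only a floor and leaves the true size of the step unsettled. Compound 3 therefore still stands alone at a limit: the limit of > 56.2 uM in this assay, at which 1 of the 4 values shown sits.

From the compounds shown here alone, whether an amine or a carboxylic acid on this aromatic ring would move the number beyond the scatter of compound 1, compound 2 and compound 4 remains open.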